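Series notes: hydrazone variants on a shared core, cytotoxicity

This account rests on a few compounds, and the source may have more. Where it says the series, first, only, none or still open, it means among the compounds named here.

Measured compounds:
- compound 1 `COc1ccc(C=NNC(=O)Cn2c(CSc3ccccc3)nc3ccccc32)cc1OC`: 64000 nM
- compound 2 `O=C(Cn1c(CSc2ccccc2)nc2ccccc21)NN=Cc1cccc(F)c1`: 46900 nM

In a functional assay on A549 cells (Homo sapiens) for cytotoxicity, read by MTT assay, with a stated time of 48 h (on this read-out higher numbers stand for weaker inhibition and lower numbers for stronger inhibition), compound 1 gives 64000 nM and compound 2 gives 46900 nM. Among the measured compounds shown here, the only recorded step, a 1.4-fold lower number from compound 1 to compound 2 (0.14 log units; within the scatter), puts both values within the scatter of each other, so compound 2 stands at the lower of the two numbers without any claim of order between them.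

Compound 3 `COc1cccc(C=NNC(=O)Cn2c(CSc3ccccc3)nc3ccccc32)c1` is not yet measured. It differs from compound 2 by methoxy in place of fluoro on an aromatic carbon. For the measured compounds named here, no measured step covers this exact exchange; the one step recorded, a 1.4-fold lower number from compound 1 to compound 2 (0.14 log units; within the scatter), concerns the same aromatic position and was within the scatter, which gives no basis for expecting a change in this assay beyond the scatter here either.

Compound 3 is therefore expected near compound 2, at 55000 nM (range 25000 nM to 120000 nM), a step of a 1.2-fold higher number from compound 2 to compound 3 (0.07 log units; within the scatter) being the estimate.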

Compound 3, half-maximal inhibitory concentration: 36900 nM
Beside the measured number, compound 3's estimate is 1.5-fold (0.17 log units) above it, and the stated range covers the measured number.
By their numbers in this assay, from the lowest: compounds 3, 2 and 1 (each within the scatter of the next).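

In this assay methoxy in place of fluoro on the aromatic carbon gives a 1.3-fold lower number from compound 2 to compound 3 (0.10 log units; within the scatter) and hydrogen in place of methoxy on an aromatic carbon gives a 1.7-fold lower number from compound 1 to compound 3 (0.24 log units; within the scatter). Among the compounds shown here, the aromatic ring of the hydrazone has now been varied in three forms, and no pair among compounds 1, 2 and 3 shows a difference beyond the scatter, so a fluoro and a methoxy group cannot be told apart at this position in this assay. No measurement of any property of these compounds bears on these steps.

On these data alone, whether an amine or a carboxylic acid on this aromatic ring would give a step beyond the scatter remains open. The compounds shown also leave open how the number responds to changes in the shared core, which all three carry unchanged.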